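Working notes: from compound 1 to compound 3

The compounds below may be only part of what the source reports. "The series", "measured", "known", "first", "only" and "open" are said of these compounds alone.

Measured so far in a functional assay on SMMC-7721 cells (Homo sapiens) for cytotoxicity, read by MTT assay, with a stated time of 24 h; a higher number here means a weaker inhibitor, a lower number a stronger inhibitor (half-maximal inhibitory concentration):
- compound 1 `O=C1/C(=C/c2ccncc2)CN(S(=O)(=O)c2ccccc2)C/C1=C\c1ccccc1F` gives 17500 nM
- compound 2 `O=C1/C(=C/c2ccncc2)CN(S(=O)(=O)c2ccc(C(F)(F)F)cc2)C/C1=C\c1ccccc1F` gives 11100 nM

Among the compounds with values here, only two numbers are available, and compound 1 stands within the scatter of its sole neighbour, compound 2. No order between the two can be read from them.

Compound 3 `O=C1/C(=C/c2ccncc2)CN(S(=O)(=O)c2ccccc2)C/C1=C\c1ccccc1C(F)(F)F` remains unmeasured. It keeps the core of compound 1 and differs by trifluoromethyl in place of fluoro on an aromatic carbon (trifluoromethyl in place of fluoro on an aromatic carbon, ortho to a large group).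

Within the data shown here, one measured step bears on this change, and only indirectly. In a 1.6-fold lower number from compound 1 to compound 2 (0.20 log units; within the scatter) a trifluoromethyl group also enters, but in place of hydrogen and at a different place in the molecule. Among the measured compounds shown here, no measured step replaces fluoro, so the size of this particular exchange remains open.

For the measured compounds named here, with compound 2 as the only guide, and its step within the scatter, no step beyond the scatter is expected in this assay here. The estimated step is a 1.3-fold lower number from compound 1 to compound 3 (0.10 log units; within the scatter) and carries no firm direction.

For compound 3 the estimated value is 14000 nM (expected range 6000 nM to 30000 nM).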

Compound 3, half-maximal inhibitory concentration: 6540 nM
The estimate for compound 3 lay 2.1-fold (0.33 log units) above the measured number; the measured number falls inside the stated range.
By their numbers in this assay, from the lowest: compounds 3, 2 and 1 (each within the scatter of the next, the first and the last beyond it).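

In this assay, within the data shown here, the exchange of 2-fluorophenyl for 2-(trifluoromethyl)phenyl gives the first step that lies beyond the scatter, though it is modest (a 2.7-fold lower number from compound 1 to compound 3 (0.43 log units; beyond the scatter)). Among these compounds, the only earlier step, with trifluoromethyl in place of hydrogen on an aromatic carbon, stayed within the scatter (a 1.6-fold lower number from compound 1 to compound 2 (0.20 log units; within the scatter)), so the number had not yet been seen to respond to any single change. This aromatic carbon, ortho to a large group, is therefore the first place in the series where a substitution gives a readable change, while no measurement shown here speaks to what lies behind the step.

Two compounds with a single change from compound 1 cannot show whether the step reflects the larger trifluoromethyl group or some other difference from fluoro, and a methoxy group, a nitrile or an amine on the same aromatic carbon would test how far the number follows the group placed there. From the compounds shown here alone, it also remains open whether the same exchange gives a similar step when the sulfonyl-bound phenyl carries trifluoromethyl, as it does in compound 2.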